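Shortening the Bridge: From Styryl to Biaryl Amide

The source may report more compounds than this note shows. Statements on the series, on what has been measured and on what is new or still open speak of the compounds shown alone.

Compound 1 `COC(=O)/C=C/c1cccc(N(Cc2ccc(/C=C/c3cccc(F)c3)cc2)C(=O)C2CCCCC2)c1` gives 86 nM in an assay on isolated protein with Bile acid receptor (Homo sapiens) as the target; a higher number here means that more compound is needed for the effect, a lower number that less compound is needed.
Compound 3 `CCOc1cccc(-c2ccc(CN(C(=O)C(C)C)c3cccc(/C=C/C(=O)OC)c3)cc2)c1` gives 173 nM in this assay.
Compound 2 `COC(=O)/C=C/c1cccc(N(Cc2ccc(-c3cccc(OC)c3)cc2)C(=O)NC(C)C)c1` gives 1370 nM in this assay.

Among the three compounds measured so far, compound 1 has the lowest number in this assay. Its nearest neighbour is compound 3, whose number sits within the usual scatter of compound 1, so no order can be read between those two. Compound 2 stands clearly apart, needing far more compound than either of the others.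

Compound 4 `COC(=O)/C=C/c1cccc(N(Cc2ccc(-c3cccc(Cl)c3)cc2)C(=O)C2CCCCC2)c1` has not yet been measured. It keeps the core of compound 1 and the same cyclohexanecarbonyl amide, and differs only in one place: 3-chlorophenyl in place of 2-(3-fluorophenyl)ethenyl on an aromatic carbon. The outer ring thus sits directly on the benzyl ring instead of being held out on a two-carbon linker.

Among the compounds with values here, no measured pair shows exactly this change, so the expectation rests on the neighbours. Compound 3, which also carries a directly attached outer ring with a small substituent, gives 173 nM, close to compound 1. Compound 4 is therefore expected to land near compound 1, with the step of a 1.7-fold higher number from compound 1 to compound 4 (0.24 log units; within the scatter) estimated to stay within the scatter or be only slightly upward. The estimate for compound 4 in this assay is 150 nM, with a range from 50 nM to 500 nM.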

Compound 4, half-maximal effective concentration: 94 nM
The estimate for compound 4 lay 1.6-fold (0.20 log units) above the measured number; the range from low to high includes it.
By their numbers in this assay, from the lowest: compounds 1, 4 and 3 (each within the scatter of the next); then compound 2.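

In this assay, with the cyclohexanecarbonyl amide and the rest of the core held the same, putting 3-chlorophenyl in place of 2-(3-fluorophenyl)ethenyl gives a 1.1-fold higher number from compound 1 to compound 4 (0.04 log units; within the scatter), the first step read directly at this position. On this aromatic carbon, para to a large group, the outer ring can therefore sit directly on the ring without the ethenyl link, and the two numbers cannot be told apart. Nothing available explains why these two groups give such matching numbers.

This step removes the ethenyl link and exchanges fluorine for chlorine together, so the compounds shown cannot separate what each part contributes. Also open, on these data alone, is how this position responds to a different kind of group, such as an amine or a carboxylic acid on the outer ring.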